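This account rests on a few compounds, and the source may have more. Where it says the series, first, only, none or still open, it means among the compounds named here.

Measured so far in an assay on isolated protein for inhibition of MAP kinase-activated protein kinase 2 (Homo sapiens), read by mobility shift assay, tested at 30 uM; on this read-out lower numbers stand for less inhibition and higher numbers for more inhibition at the one concentration tested (going by the name of the read-out): compound 1 `Cc1cc2[nH]nc(N)c2c(=O)[nH]1` gives 30%; compound 2 `Nc1n[nH]c2cc(-c3cccs3)[nH]c(=O)c12` gives 58%; compound 3 `Nc1n[nH]c2cc(CC3CCNCC3)[nH]c(=O)c12` gives 35%.

Compound 1 is the lowest of the three numbers, though compound 3 stands within the scatter of it; compound 2 stands beyond it, as the step of a number 28 percentage points higher from compound 1 to compound 2 (beyond the scatter) shows. Compound 4 `Cc1cc2c(c(N)nn2C)c(=O)[nH]1` differs from compound 1 in one place: methyl in place of hydrogen on an aromatic nitrogen. Neither measured step touches that aromatic nitrogen: a number 28 percentage points higher from compound 1 to compound 2 (beyond the scatter) and a number 5 percentage points higher from compound 1 to compound 3 (within the scatter) both alter the other side of the shared core, so they give no direct guide. Without a comparable step, the expectation is a change of no more than the scatter. Compound 4 is estimated at 22%, in the range 0% to 45%, meaning an expected step of a number 8 percentage points lower from compound 1 to compound 4 (within the scatter).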

Compound 4, a percentage reported as inhibition, at one concentration (the size of the read-out at that concentration, not a potency): 29%
Compound 4: middle estimate off by 7 percentage points, on the low side; the range from low to high includes it.
By their numbers in this assay, from the lowest: compounds 4, 1 and 3 (each within the scatter of the next); then compound 2.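

In this assay, methyl on the aromatic nitrogen gives a number 1 percentage points lower from compound 1 to compound 4 (within the scatter), so at this concentration the change cannot be told apart from the hydrogen it replaces. Within the data shown here, this is the first reading at this nitrogen, as the earlier steps changed only the other side of the shared core. Nothing measured here gives a reason for the result.

On these data alone, whether a benzyl group or a longer chain ending in an amine on this nitrogen would behave the same remains open. So does whether methyl there would give a similar step alongside the thiophen-2-yl of compound 2.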